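The source may hold more compounds than are shown below. What is called first, only, known or untested is meant among the compounds shown, and "the series" means these compounds.

Measured so far:
Compound 1 `O=C1/C(=C/c2ccc(O)cc2)Oc2cc(O)ccc21` gives 69% in an assay on cells for inhibition of Tyrosinase (Homo sapiens), tested at 0.1 mM; a lower number here means less inhibition, a higher number more inhibition at the concentration tested (going by the name of the read-out).
Compound 2 `CCOc1ccc(/C=C2\Oc3cc(O)cc(O)c3C2=O)cc1` gives 5% in this assay.

Compound 2 holds the lowest of the two numbers in this assay; compound 1 stands above it by a margin beyond the usual scatter, but the two differ in more than one place, so no single change can be read from that gap. Compound 3 `CCCc1ccc(/C=C2\Oc3cc(O)cc(O)c3C2=O)cc1` differs from compound 2 in one place only: propyl in place of ethoxy on an aromatic carbon. Within the data shown here, no measured pair shows the effect of this change, so the expectation rests on compound 2 and its value of 5%. A small rise is expected, a step of a number 10 percentage points higher from compound 2 to compound 3 (within the scatter) from compound 2, one that may well stay within the scatter. Compound 3 is therefore expected to give about 15% in this assay, with a range from 0% to 40%.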

Compound 3, a percentage reported as inhibition, at one concentration (the size of the read-out at that concentration, not a potency): 5%
The estimate for compound 3 lay 10 percentage points above the measured number; the measured number falls inside the stated range.
By their numbers in this assay, from the lowest: compounds 2 and 3 (each within the scatter of the next); then compound 1.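

Propyl in place of ethoxy on an aromatic carbon, para to a large group, gives no change at the digits printed from compound 2 to compound 3 (within the scatter) in this assay and is the first step in the series that can be read at a single place. The hydrogen-bond acceptor of ethoxy leaves with this change, and the read-out stays within the scatter. Among these compounds, with compound 3 at 5% as well, this step shows only that these two groups are not told apart at this place in this assay, and no measurement at hand gives a reason for that.

On these data alone, whether an amine, a carboxylic acid or a longer chain such as hexyl at this place would lift the number remains open. The gap between compound 1 and compound 2 also remains unassigned, as those two differ in more than one place.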